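The source may report more compounds than this note shows. Statements on the series, on what has been measured and on what is new or still open speak of the compounds shown alone.

Measured compounds:
Compound 1, `Cc1ccsc1C(c1c(C)noc1C)N1CCN(c2ncnc3c2cnn3-c2ccccc2)CC1`, gives > 25000 nM in a functional assay on cells (Rhabdomyosarcoma cell, Homo sapiens) for cytotoxicity; on this read-out higher numbers stand for weaker inhibition and lower numbers for stronger inhibition; this is a limit of the assay, not a number.
Compound 2, `Brc1ccc(C(c2ccccc2)N2CCN(c3ncnc4c3cnn4-c3ccccc3)CC2)cc1`, gives > 25000 nM in this assay; again this is a limit, not a number.
Compound 3, `Cc1noc(C)c1C(c1ccccc1)N1CCN(c2ncnc3c2cnn3-c2ccccc2)CC1`, gives > 25000 nM in this assay; again a limit, not a number.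

Compound 3 therefore stands exactly where the other two measured compounds stand, at the limit of > 25000 nM in this assay, at which 3 of the 3 values shown sit. No number is known for it; only that its cytotoxicity is too weak to register within the tested range. The two steps leading to it carry no readable size: a step that the two limits leave unreadable from compound 1 to compound 3 and a step that the two limits leave unreadable from compound 2 to compound 3 are unreadable because both ends of each step sit at the limit of > 25000 nM in this assay, at which 3 of the 3 values shown sit.

Compound 4, `N#Cc1cccc(C(c2ccccc2)N2CCN(c3ncnc4c3cnn4-c3ccccc3)CC2)c1`, differs from compound 3 in one place: 3-cyanophenyl in place of 3,5-dimethyl-1,2-oxazol-4-yl on a saturated chain carbon bound to an amine nitrogen in a ring and an aromatic carbon. Neither measured step speaks to this change in a readable way; three different aromatic groups on the saturated chain carbon all left the read-out at the limit. The expectation for the step in this assay is therefore none beyond the scatter, with compound 4 most likely also reported only as a limit, expected as a step that the limit leaves unreadable from compound 3 to compound 4. For compound 4 the estimated value is 40000 nM, within an expected range from 15000 nM to 150000 nM.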

Compound 4, half-maximal inhibitory concentration: > 25000 nM
Compound 4: a limit, no number; the forecaster's own chance of this, stated with the estimate: 85%; the middle value lies beyond the limit too.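

Compound 4 also gives only a limit, so neither its step from compound 3 nor its step from compound 2 can be read, because both ends of each step sit at the same limit: the limit of > 25000 nM in this assay, at which 4 of the 4 values shown sit.

The compounds shown leave open whether any aromatic group on the saturated chain carbon would give an actual number in this assay, and how these four compounds compare.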